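A few compounds are considered here, and "the series" means these few. Any claim that something is new, unique, unknown or untested is made for them only; others in the source may bear on it.

Working notes on the series. The shared core of compound 1 `Clc1cccc(-n2cc(CSc3nc4ccccc4s3)nn2)c1` carries an aryl group on an aromatic nitrogen; in a functional assay on the whole organism (strain Albino Wistar) for inhibition, with Rattus norvegicus as the target, read by paw edema, with stated times of 1 h and 3 h, at a dose of 10 mg/kg by the oral route (a lower number here means less inhibition, a higher number more inhibition at the dose given (going by the name of the read-out)), compound 1 gives 35%. Going by the values given here, compound 2 `Cc1ccccc1-n1cc(CSc2nc3ccccc3s2)nn1` keeps that core, and in this assay compound 2 gives 47.3%, the highest of the two numbers so far, the step being a number 12.3 percentage points higher from compound 1 to compound 2 (beyond the scatter). Compound 3 `OCC(O)Cn1cc(CSc2nc3ccccc3s2)nn1` is not yet measured in this assay. The change from compound 2 to compound 3 is 2,3-dihydroxypropyl in place of 2-methylphenyl on an aromatic nitrogen. Among the compounds with values here, the only measured step, a number 12.3 percentage points higher from compound 1 to compound 2 (beyond the scatter), exchanges one six-membered aromatic ring for another; no measured step exchanges an aromatic ring for a chain, so it bears on this change only in showing that the group on the aromatic nitrogen shifts the read-out by a modest amount. A step in either direction, of about that size or somewhat larger, is expected. The estimated step is a number 14.3 percentage points lower from compound 2 to compound 3 (beyond the scatter). For compound 3 the expected value in this assay is 33%, within 15% to 52%.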

Compound 3, a percentage reported as inhibition, in the whole organism at one dose (the size of the read-out at that dose, not a potency): 56.7%
Beside the measured number, compound 3's estimate is 23.7 percentage points below it; measured number above the stated range.
By their numbers in this assay, from the lowest: compound 1; then compounds 2 and 3 (each within the scatter of the next).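

In this assay, an aromatic ring on the aromatic nitrogen is now exchanged for an open chain, and the step of a number 9.4 percentage points higher from compound 2 to compound 3 (within the scatter) shows that 2,3-dihydroxypropyl and 2-methylphenyl cannot be told apart at this position. The step of a number 21.7 percentage points higher from compound 1 to compound 3 (beyond the scatter) shows that the same chain also holds up against 3-chlorophenyl, so an aromatic ring on this nitrogen is not required for the read-out in these compounds. Nothing available explains this result or ties it to any feature of the chain.

The compounds shown leave open whether the two hydroxyl groups contribute, which a plain propyl chain would test against 2,3-dihydroxypropyl. They also leave open how an amine or a carboxylic acid at the end of a chain on this nitrogen would read.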